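The source may report more compounds than this note shows. Statements on the series, on what has been measured and on what is new or still open speak of the compounds shown alone.

Measured compounds:
Compound 1, `COc1c(N2C[C@H]3CCCN(Cc4cn(CCCN5C(=O)C(=O)c6cc(F)ccc65)nn4)[C@H]3C2)c(F)cc2c(=O)c(C(=O)O)cn(C3CC3)c12`: 16 ug/mL
Compound 2, `COc1c(N2C[C@H]3CCCN(Cc4cn(CCCN5C(=O)C(=O)c6ccccc65)nn4)[C@H]3C2)c(F)cc2c(=O)c(C(=O)O)cn(C3CC3)c12`: 16 ug/mL
Compound 3, `CO/N=C1/C(=O)N(CCCn2cc(CN3CCC[C@@H]4CN(c5c(F)cc6c(=O)c(C(=O)O)cn(C7CC7)c6c5OC)C[C@@H]43)nn2)c2ccc(F)cc21`: 4 ug/mL

In an ADME assay on Vero cells (Chlorocebus sabaeus) for cytotoxicity, read by MTT assay, with a stated time of 72 h (a lower number here means that less compound is tolerated, a higher number that more compound is tolerated), compound 1 gives 16 ug/mL. Compound 2 gives 16 ug/mL in the same assay. The two differ by hydrogen in place of fluoro on an aromatic carbon, and the step of no change at the digits printed from compound 1 to compound 2 (within the scatter) shows that this change left the cytotoxic concentration where it was. Compound 3 gives 4 ug/mL in this assay, a lower number than either compound 1 or compound 2, and in both cases the gap lies beyond the scatter. The difference between the core of compound 3 and the core of compound 1 is not broken down here.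

Compound 4, `CO/N=C1/C(=O)N(CCCn2cc(CN3CCC[C@@H]4CN(c5c(F)cc6c(=O)c(C(=O)O)cn(C7CC7)c6c5OC)C[C@@H]43)nn2)c2ccccc21`, has not yet been measured. It differs from compound 3 by hydrogen in place of fluoro on an aromatic carbon, which is the same change as that from compound 1 to compound 2, at a place described in the same words. The expected step of no change at the digits printed from compound 3 to compound 4 (within the scatter) is estimated to be small because the earlier step of no change at the digits printed from compound 1 to compound 2 (within the scatter) was flat, and nothing among the three measured compounds suggests that the change should act differently on the core of compound 3. Compound 4 is therefore expected to give about 4 ug/mL in this assay, with a likely range from 2 ug/mL to 8 ug/mL.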

Compound 4, half-maximal cytotoxic concentration: 16 ug/mL
For compound 4 the middle estimate is 4.0-fold (0.60 log units) below the measured one, and the stated range ends below it.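

In this assay, hydrogen in place of fluoro on an aromatic carbon gives a 4.0-fold higher number from compound 3 to compound 4 (0.60 log units; beyond the scatter), set against no change at the digits printed from compound 1 to compound 2 (within the scatter) on the core of compound 1. Within the data shown here, the result of this change therefore did not carry over from one core to the other, and the flat step seen first was no safe guide to the second pair: the same change on two cores in this assay, no change at the digits printed (within the scatter) from compound 1 to compound 2 and a 4.0-fold higher number (0.60 log units; beyond the scatter) from compound 3 to compound 4, 4.0-fold (0.60 log units) apart, beyond the scatter of two such steps This shows that, for these two pairs and in this one cell assay, the same replacement can leave the number unmoved on one core and raise it on another, but with only two pairs it does not show which feature of the cores sets the two steps apart, why the step appears on one core alone, or how the change would behave on any further core.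

The compounds shown leave open whether a chloro or a methyl group at that same place on the ring would follow the fluoro compounds or the hydrogen compounds on each core. They also leave open whether the gap between the two steps would persist with a longer chain in the molecule, or with an amine on that ring.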